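This account rests on a few compounds, and the source may have more. Where it says the series, first, only, none or still open, it means among the compounds named here.

Measured in a functional assay on HT-29 cells (Homo sapiens) for inhibition, read by MTT assay, with a stated time of 48 h; on this read-out higher numbers stand for weaker inhibition and lower numbers for stronger inhibition:

- Compound 1 `COc1ccc(-n2c(SCc3ccc(C)cc3)nnc2-c2cc(OC)c(OC)c(OC)c2)cc1`: > 60000 nM, a limit of the assay
- Compound 2 `COc1ccc(CSc2nnc(-c3cc(OC)c(OC)c(OC)c3)n2-c2ccc(N(C)C)cc2)cc1`: > 60000 nM, a limit of the assay
- Compound 3 `COc1cc(-c2nnc(SCc3ccc(C)cc3)n2-c2ccc(N(C)C)cc2)cc(OC)c1OC`: 27500 nM

Compound 3 is the only one of the three with an actual number, and it is the most active of them. Compound 1 and compound 2 stand at the limit of > 60000 nM in this assay, at which 2 of the 3 values shown sit.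

Compound 4 `COc1cc(-c2nnc(SCC(=O)c3ccc4ccccc4c3)n2-c2ccc(N(C)C)cc2)cc(OC)c1OC` has not yet been measured. It differs from compound 3 in one place, with (naphthalen-2-yl)carbonyl in place of 4-methylphenyl on a saturated chain carbon bound to a sulfur.

Two measured steps are relevant, and both are beyond the scatter. The closer one is an at least 2.1-fold lower number from compound 2 to compound 3 (0.33 log units; beyond the scatter), with methyl in place of methoxy on an aromatic carbon, a change within the group that now leaves. The other is an at least 2.1-fold lower number from compound 1 to compound 3 (0.33 log units; beyond the scatter), with dimethylamino in place of methoxy on an aromatic carbon, and compound 4 keeps that dimethylamino group.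

Neither step involves a carbonyl, so the data fix the direction only loosely and the size hardly at all. A clear move to a lower number is nevertheless expected in this assay, given that an at least 2.1-fold lower number from compound 2 to compound 3 (0.33 log units; beyond the scatter) shows this end of the molecule can shift the read-out. The expected change is an 18-fold lower number from compound 3 to compound 4 (1.26 log units; beyond the scatter). Compound 4 is estimated at 1500 nM, with an expected range of 30 nM to 40000 nM.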

Compound 4, half-maximal inhibitory concentration: > 60000 nM
Compound 4: a limit, no number; the forecaster's own chance of this, stated with the estimate: 10%; at least 40-fold (1.60 log units) between middle value and limit.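

In this assay, the saturated chain carbon bound to a sulfur proves sensitive to a large exchange: (naphthalen-2-yl)carbonyl in place of 4-methylphenyl gives an at least 2.1-fold higher number from compound 3 to compound 4 (0.33 log units; beyond the scatter). Until now, this end of the molecule had been seen only through a small change on its aromatic ring, an at least 2.1-fold lower number from compound 2 to compound 3 (0.33 log units; beyond the scatter), whereas exchanging the whole group for one with a carbonyl and two six-membered aromatic rings moves the read-out towards weaker inhibition. The step from compound 2 to compound 4 joins two limits and cannot be read, and compound 3 remains the only compound with an actual number: the limit of > 60000 nM in this assay, at which 3 of the 4 values shown sit.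

The carbonyl and the naphthalene rings enter together, so the compounds shown do not tell which of the two goes with the loss, and the limit leaves its full size open. They also leave open how a phenylcarbonyl group, which keeps the carbonyl with a single ring, or a carboxylic acid or an amine at the end of a longer chain at this place would read in this assay.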